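The source may report more compounds than this note shows. Statements on the series, on what has been measured and on what is new or still open speak of the compounds shown alone.

Measured so far in an ADME assay on the whole organism for inhibition, with Oryza sativa as the target, with a stated time of 7 days; a higher number here means a weaker inhibitor, a lower number a stronger inhibitor:
compound 1, `CCCCC(=O)ON1C(=O)COc2ccc(Cl)cc21`, gives 2000 nM
compound 2, `CCC(=O)ON1C(=O)COc2c(Cl)cccc21`, gives 859000 nM
compound 3, `CCC(=O)ON1C(=O)COc2ccc(Cl)cc21`, gives 3000 nM

Compound 1 and compound 3 share a core and differ by ethyl in place of hydrogen on a saturated chain carbon, two bonds along the chain from a carbonyl carbon. That change gives a 1.5-fold lower number from compound 3 to compound 1 (0.18 log units; within the scatter), so the two numbers cannot be told apart in this assay. Compound 2 stands on a core that has the same atoms as compound 3 joined differently; the difference between the two cores is not broken down here. What the numbers show is that compound 2 gives the highest value of the three, far beyond the scatter from both compound 3 and compound 1.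

Compound 4, `CCCCC(=O)ON1C(=O)COc2c(Cl)cccc21`, is not yet measured. It differs from compound 2 by ethyl in place of hydrogen on a saturated chain carbon, two bonds along the chain from a carbonyl carbon, which is the same change as the one from compound 3 to compound 1; it appears in no other pair among these compounds. Since the change from compound 3 to compound 1 stayed within the scatter, the expectation is a similarly small step, a 1.4-fold lower number from compound 2 to compound 4 (0.16 log units; within the scatter), because compound 2 gives 859000 nM and the matching step was a 1.5-fold lower number from compound 3 to compound 1 (0.18 log units; within the scatter). Compound 4 is therefore expected to give about 600000 nM in this assay, with a likely range from 200000 nM to 1800000 nM.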

Compound 4, half-maximal inhibitory concentration: 712000 nM
Compound 4: the middle estimate sits 1.2-fold (0.07 log units) below what was measured; the measured number falls inside the stated range.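

In this assay, putting ethyl in place of hydrogen on a saturated chain carbon, two bonds along the chain from a carbonyl carbon, gives a 1.2-fold lower number from compound 2 to compound 4 (0.08 log units; within the scatter) and leaves the two numbers indistinguishable. Set beside the earlier step, the change behaves alike on both cores, with no difference in size that can be detected: the same change on two cores in this assay, a 1.5-fold lower number (0.18 log units; within the scatter) from compound 3 to compound 1 and a 1.2-fold lower number (0.08 log units; within the scatter) from compound 2 to compound 4, 1.2-fold (0.09 log units) apart, within the scatter of two such steps. Among the compounds shown here, this shows only that the change made no step beyond the scatter on either core, so the agreement is between two steps that cannot themselves be told from no change, and it rests on two cores alone, which does not establish that the same would hold on a further core.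

The compounds shown leave open whether a chain longer than the butylcarbonyl, or an amine or a carboxylic acid carried on the chain, would give a step beyond the scatter on either core. They also leave open what a bromine or a methoxy group in place of the chlorine would do to the number, and whether the change in the chain would still give so small a step there.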